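This account rests on a few compounds, and the source may have more. Where it says the series, first, only, none or still open, it means among the compounds named here.

Of the compounds shown here, three have been read in an ADME assay on microsomes from liver (Rattus norvegicus) for metabolic stability; on this read-out higher numbers stand for fast clearance and lower numbers for slow clearance. Compound 1 (`CNC(=O)[C@@H]1CC[C@H](c2ccc(OCc3ccccc3F)cc2)N1`) gives 9.3 mL.min-1.g-1, compound 2 (`N#Cc1ccccc1COc1ccc([C@H]2CC[C@@H](C(N)=O)N2)cc1`) gives 1.4 mL.min-1.g-1 and compound 3 (`NC(=O)[C@@H]1CC[C@H](c2ccc(OCc3ccc(F)cc3)cc2)N1`) gives 1.8 mL.min-1.g-1. Compound 3 thus stands within the scatter of compound 2, while the number for compound 1 is higher than both by more than the scatter.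

Compound 4 (`NC(=O)[C@@H]1CC[C@H](c2ccc(OCc3ccccc3)cc2)N1`) has not yet been measured. It differs from compound 3 by hydrogen in place of fluoro on an aromatic carbon, or 4-fluorophenyl to phenyl when the same difference is cut one bond further out.

Within the data shown here, no measured step makes this exact change. Compound 1 differs from compound 3 in more than one place, so it offers no clean comparison. The closest evidence is the step that brings in the 4-fluorophenyl group, a 1.3-fold higher number from compound 2 to compound 3 (0.11 log units; within the scatter), and a change at that same group is therefore expected to stay similarly small.

The expected step is a 1.1-fold higher number from compound 3 to compound 4 (0.05 log units; within the scatter), and no shift beyond the scatter is anticipated. The estimate for compound 4 is 2 mL.min-1.g-1, with an expected range from 1 mL.min-1.g-1 to 4 mL.min-1.g-1.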

Compound 4, intrinsic clearance in microsomes: 0.5 mL.min-1.g-1
Beside the measured number, compound 4's estimate is 4.0-fold (0.60 log units) above it; the whole stated range lies above it.
By their numbers in this assay, from the lowest: compound 4; then compounds 2 and 3 (each within the scatter of the next); then compound 1.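

Among these compounds, until now the only step touching this ring, a 1.3-fold higher number from compound 2 to compound 3 (0.11 log units; within the scatter), suggested that this assay hardly responds to what the ring carries, yet the plain phenyl separates from both substituted compounds: a 3.6-fold lower number from compound 3 to compound 4 (0.56 log units; beyond the scatter), and a 2.8-fold lower number from compound 2 to compound 4 (0.45 log units; beyond the scatter). A single fluoro, one heavy atom on an aromatic carbon para to a large group, is thus enough to move this read-out beyond the scatter, and among compound 2, compound 3 and compound 4 the two compounds carrying a substituent on this ring stand together, with the unsubstituted phenyl on the low side. Nothing available bears on why this one atom matters so much here.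

Going by these compounds, whether the lower number of the plain phenyl also holds against other groups on this ring, such as chloro, methoxy or an amine, remains open, as does how much depends on the place of the substituent rather than on its identity. Compound 1 differs from the others in more than one place, so the parts played by its 2-fluorophenyl group and by the methyl on its amide cannot be told apart.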